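Series notes: benzylamino for methoxy on the carbonyl carbon

The source may hold more compounds than are shown below. What is called first, only, known or untested is meant among the compounds shown, and "the series" means these compounds.

Measured so far in an assay on HEK293 cells for inhibition of Voltage-dependent T-type calcium channel subunit alpha-1G (Homo sapiens), tested at 10 uM; a higher number here means more inhibition at the concentration tested (going by the name of the read-out), a lower number less inhibition:
compound 1 `COC(=O)CC1c2ccccc2N=C(NCCCCCNC(=O)OC(C)(C)C)N1c1ccc(-c2ccccc2)cc1`: 86.5%
compound 2 `COC(=O)CC1c2ccccc2N=C(Nc2ccc(-c3ccccc3)cc2)N1CCCCCN`: 84.1%
compound 3 `CC(C)(C)OC(=O)NCCCCCNC1=Nc2ccccc2C(CC(=O)NCc2ccccc2)N1c1ccc(-c2ccccc2)cc1`: 88.3%

All three measured compounds sit close together in this assay. The values of compound 1 and compound 2 are within the scatter of each other, as are those of compound 2 and compound 3, so no ordering among them is claimed. The difference between the cores of compound 1 and compound 2 is not broken down here.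

One change has been made once and measured: from compound 1 to compound 3, (benzylamino in place of methoxy on a carbonyl carbon). The step it made is a number 1.8 percentage points higher from compound 1 to compound 3 (within the scatter), that is, no change of the read-out that can be told from repeat scatter.

Compound 4 `NCCCCCN1C(Nc2ccc(-c3ccccc3)cc2)=Nc2ccccc2C1CC(=O)NCc1ccccc1` is not yet measured. It differs from compound 2 by benzylamino in place of methoxy on a carbonyl carbon, at the same place as the change from compound 1 to compound 3, so this is the same change made a second time on a different core. Among the compounds with values here, only one example of the change exists, so the expectation rests on that single step. The step from compound 2 to compound 4 in this assay is expected to be a number 1.9 percentage points higher from compound 2 to compound 4 (within the scatter), small and within the scatter, because the measured step was a number 1.8 percentage points higher from compound 1 to compound 3 (within the scatter). The expected value for compound 4 in this assay is 86%, with a range from 74% to 96%.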

Compound 4, a percentage reported as inhibition, at one concentration (the size of the read-out at that concentration, not a potency): 91.8%
The estimate for compound 4 lay 5.8 percentage points below the measured number; the measured number falls inside the stated range.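

With the second example in hand, the change of benzylamino in place of methoxy on the carbonyl carbon can now be read on two cores in this assay, and the new step is a number 7.7 percentage points higher from compound 2 to compound 4 (within the scatter). Set beside the earlier step, the two cannot be told apart, so the data give no sign that the outcome of this change depends on the core: the same change on two cores in this assay, a number 1.8 percentage points higher (within the scatter) from compound 1 to compound 3 and a number 7.7 percentage points higher (within the scatter) from compound 2 to compound 4, 5.9 percentage points apart, within the scatter of two such steps Neither step stands clear of the scatter, so the change is not shown to raise or lower the read-out on either core, and a read-out taken at one concentration says nothing about potency, while two cores give no assurance for other cores in the series.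

The compounds shown leave open how other groups on this carbonyl carbon would read, such as a carboxylic acid, a primary amide or a phenethylamino group with its longer chain to the phenyl ring. Also open, on these data alone, is whether either step would stand clear of the scatter at a lower test concentration, where the values may not lie so close together.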